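A tert-butylphenyl group takes over at the sulfur

The compounds below may be only part of what the source reports. "The series", "measured", "known", "first", "only" and "open" are said of these compounds alone.

Of the compounds shown here, three have numbers so far in a functional assay on A549 cells (Homo sapiens) for inhibition, read by CCK-8 assay, with a stated time of 72 h, tested at 2 uM (a higher number here means more inhibition of growth at the concentration tested, a lower number less inhibition of growth), on this scale. Compound 1 (`CCc1ccc(SCc2ccc(/C=C/C(=O)Nc3ccccc3N)cc2)cc1`) gives 60.7% in this read-out, compound 2 (`Nc1ccccc1NC(=O)c1ccc(CSc2cccc(F)c2)cc1`) gives 46.9% and compound 3 (`Nc1ccccc1NC(=O)/C=C/c1ccc(CSc2ccc(C(F)(F)F)cn2)cc1`) gives 51.7% on the same scale. Compound 3 holds the second highest of the three numbers, yet its gaps to the other two lie within the scatter. Compound 4 (`CC(C)(C)c1ccc(SCc2ccc(/C=C/C(=O)Nc3ccccc3N)cc2)cc1`) is still to be measured. It differs from compound 3 in one place (4-(tert-butyl)phenyl in place of 5-(trifluoromethyl)pyridin-2-yl on a sulfur): 4-(tert-butyl)phenyl in place of 5-(trifluoromethyl)pyridin-2-yl on a sulfur.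

Going by the values given here, compound 2 differs from compound 3 in more than one place and offers no clean step. Among the compounds with values here, the one measured step at this sulfur swapped 4-ethylphenyl for the same 5-(trifluoromethyl)pyridin-2-yl, and it came out as a number 9 percentage points lower from compound 1 to compound 3 (within the scatter) in this assay when tested. Compound 4 carries a phenyl with an alkyl group on this sulfur, as compound 1 does, so the reverse direction seems the better guess, though nothing measured yet covers tert-butyl itself. The expected change is a number 6.3 percentage points higher from compound 3 to compound 4 (within the scatter) in this assay and no larger than the scatter. Compound 4 is estimated at 58% with an expected range from 45% to 70% when measured.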

Compound 4, percent growth inhibition at one concentration: 71.5%
Beside the measured number, compound 4's estimate is 13.5 percentage points below it, and the stated range ends below it.
By their numbers in this assay, from the lowest: compounds 2, 3 and 1 (each within the scatter of the next, the first and the last beyond it); then compound 4.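

Going by these compounds alone, at this sulfur, 4-(tert-butyl)phenyl in place of 5-(trifluoromethyl)pyridin-2-yl gives a number 19.8 percentage points higher from compound 3 to compound 4 (beyond the scatter) in this assay, the first step at this place to clear the scatter, since the earlier swap there stayed within it. The second step is narrower, with the phenyl ring kept and only the alkyl group on it altered: tert-butyl in place of ethyl on an aromatic carbon gives a number 10.8 percentage points higher from compound 1 to compound 4 (beyond the scatter), so this one group on the ring is enough to move the number beyond the scatter. Nothing available explains why either step runs in this direction.

The step from compound 3 to compound 4 alters the ring nitrogen and swaps trifluoromethyl for tert-butyl at the same time, so the compounds shown cannot say how much of the gain belongs to each change. They also leave open how a phenyl on this sulfur would behave with a different group in place of the tert-butyl, such as a methoxy group, an amine or a carboxylic acid.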